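The compounds below may be only part of what the source reports. "The series", "measured", "known", "first", "only" and "open" are said of these compounds alone.

Series notes. Compound 1 `Cc1c(Nc2nc(N)c3c(C#N)c(N4CCC[C@H]4C)n(C)c3n2)cnn1[C@H]1CCOC1` and compound 2 `Cc1c(Nc2nc(N)c3c(C#N)c(N4CCC[C@H]4C)n(C)c3n2)cnn1C1COC1` share the core and differ only in the group on the aromatic nitrogen. In an assay on isolated protein for inhibition of Leucine-rich repeat serine/threonine-protein kinase 2 variant G2019S (Homo sapiens), read by TR-FRET and LanthaScreen, with stated times of 50 min and 30 min, in the presence of a further agent that is not named here (on this read-out higher numbers stand for weaker inhibition and lower numbers for stronger inhibition), compound 1 gives 14 nM; in the same assay compound 2 gives 37 nM, so compound 2 holds the highest of the two numbers, the step of a 2.6-fold higher number from compound 1 to compound 2 (0.42 log units; beyond the scatter) lying beyond the scatter. Compound 3 `Cc1c(Nc2nc(N)c3c(C#N)c(N4CCC[C@H]4C)n(C)c3n2)cnn1CC(C)(C)O` is not yet measured; it differs from compound 2 by 2-hydroxy-2-methylpropyl in place of oxetan-3-yl on an aromatic nitrogen. Among the measured compounds shown here, the only measured step at this position, from oxolan-3-yl to oxetan-3-yl, moved the number modestly upward; no step to an open-chain group with a hydroxyl is available, so the direction is open. A step of at most modest size is expected, a 1.2-fold lower number from compound 2 to compound 3 (0.09 log units; within the scatter), with the number of compound 3 expected near 30 nM and likely between 10 nM and 90 nM.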

Compound 3, half-maximal inhibitory concentration: 35 nM
Compound 3: the middle estimate sits 1.2-fold (0.07 log units) below what was measured; the range from low to high includes it.
By their numbers in this assay, from the lowest: compound 1; then compounds 3 and 2 (each within the scatter of the next).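

In this assay the ring of compound 2 can give way to the open-chain 2-hydroxy-2-methylpropyl group, which has no ring and adds a hydrogen-bond donor, with a 1.1-fold lower number from compound 2 to compound 3 (0.02 log units; within the scatter) and no separation between the two numbers. Against the larger ring the same chain gives a 2.5-fold higher number from compound 1 to compound 3 (0.40 log units; beyond the scatter) and leaves compound 1, with its oxolan-3-yl group, alone with the lowest number of the three, so a ring as such is not what sets compound 2 and compound 3 apart from compound 1. No measurement is at hand that accounts for these numbers.

Still open, as far as these compounds go, is 2-methylpropyl, the same chain without its hydroxyl, which would show what the hydroxyl contributes at this position. Open as well are a primary amine or a carboxylic acid carried on a chain of this kind.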